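Swapping a hydroxypyrrolidine sulfonamide for a cyclobutyl sulfone

A few compounds are considered here, and "the series" means these few. Any claim that something is new, unique, unknown or untested is made for them only; others in the source may bear on it.

Compound 1, with the structure `O=C([C@@H]1CCCN(S(=O)(=O)c2ccc(S(=O)(=O)N3CC[C@@H](O)C3)cc2)C1)N1CCC(F)(F)CC1`, was tested in a functional assay on MIA PaCa-2 cells (Homo sapiens) for inhibition, read by MTT assay, with a stated time of 3 days (on this read-out lower numbers stand for stronger inhibition and higher numbers for weaker inhibition), where compound 1 gives 135 nM. Among the measured compounds shown here, its only measured companion is compound 2, with the structure `CCN(CC)S(=O)(=O)c1ccc(S(=O)(=O)N2CCC[C@@H](C(=O)N3CCC(O)CC3)C2)cc1`, and in this assay compound 2 gives 230 nM. These two numbers lie within the usual scatter of each other, so neither compound can be called the stronger inhibitor. Compound 3, with the structure `O=C([C@@H]1CCCN(S(=O)(=O)c2ccc(S(=O)(=O)C3CCC3)cc2)C1)N1CCC(F)(F)CC1`, has not yet been measured. It differs from compound 1 in one place: cyclobutyl in place of 3-hydroxypyrrolidin-1-yl on a sulfonyl sulfur. For the measured compounds named here, no measured pair shows what such a change does, so the expectation rests on the structural change alone. Removing a group that carries a hydrogen-bond donor and an acceptor, and putting a plain carbon ring in its place, is expected to weaken inhibition somewhat in this assay, giving a step of a 2.0-fold higher number from compound 1 to compound 3 (0.30 log units; within the scatter). Compound 3 is therefore estimated at 270 nM, within a range from 80 nM to 900 nM.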

Compound 3, half-maximal inhibitory concentration: 12.6 nM
Compound 3: the middle estimate sits 21-fold (1.33 log units) above what was measured, and the stated range ends above it.
By their numbers in this assay, from the lowest: compound 3; then compounds 1 and 2 (each within the scatter of the next).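

Among the compounds shown here, replacing 3-hydroxypyrrolidin-1-yl with cyclobutyl on this sulfonyl sulfur gives an 11-fold lower number from compound 1 to compound 3 (1.03 log units; beyond the scatter) in this assay, the first change here to lie beyond the scatter. This position therefore tolerates losing the hydrogen-bond donor and acceptor of the leaving group, and the carbon-only ring gives the stronger inhibition of this pair. Nothing measured here explains the size of this step.

The swap alters ring size and removes the ring nitrogen and the hydroxyl all at once, so this pair cannot separate their contributions. Going by these compounds, it also remains open whether a plain pyrrolidin-1-yl, a cyclopentyl ring or an open chain such as isopropyl on the same sulfur would match cyclobutyl.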